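Notes on the aryl amine swap toward compound 4

A few compounds are considered here, and "the series" means these few. Any claim that something is new, unique, unknown or untested is made for them only; others in the source may bear on it.

Measured so far:
compound 1 `COc1ccc(Nc2nc(-c3cccc(F)c3)nc3ccc(F)cc23)cc1` gives 48400 nM
compound 2 `Fc1cccc(-c2nc(Nc3ccccc3F)c3cc(F)ccc3n2)c1` gives > 50000 nM
compound 3 `Fc1cccc(-c2nc(Nc3cccc(Cl)c3)c3cc(F)ccc3n2)c1` gives > 50000 nM

For the measured compounds named here, in a functional assay on MCF7 cells (Homo sapiens) for cytotoxicity, read by MTT assay, with a stated time of 48 h (on this read-out higher numbers stand for weaker inhibition and lower numbers for stronger inhibition), compound 1 gives 48400 nM, the only actual number among the three measured compounds. Compound 2 sits at the limit > 50000 nM, which is a limit of the assay and not a number. Compound 3 likewise sits at the limit > 50000 nM. Going by the values given here, compound 1 therefore stands alone as the single readable value; the other two steps from it are floored, with an at least 1.0-fold higher number from compound 1 to compound 2 (0.01 log units; that floor lies within the scatter) and an at least 1.0-fold higher number from compound 1 to compound 3 (0.01 log units; that floor lies within the scatter), and the size of a step that the two limits leave unreadable from compound 2 to compound 3 cannot be read, because of the limit of > 50000 nM in this assay, at which 2 of the 3 values shown sit.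

Compound 4 `Fc1cccc(-c2nc(Nc3ccccc3Br)c3cc(F)ccc3n2)c1` differs from compound 1 by 2-bromophenyl in place of 4-methoxyphenyl on a nitrogen on an aromatic ring. This resembles the change from compound 1 to compound 2, where the number rose at least to the limit. The expectation for compound 4 is a step of a 1.4-fold higher number from compound 1 to compound 4 (0.16 log units; within the scatter) in this assay, toward a weaker inhibition, with a strong chance that only a limit is reported. The estimate for compound 4 is 70000 nM, ranging from 30000 nM to 200000 nM.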

Compound 4, half-maximal inhibitory concentration: > 50000 nM
Compound 4 was reported as a limit; the forecaster's own chance of this, stated with the estimate: 70%; the middle value lies beyond the limit too.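

In this assay, 2-bromophenyl in place of 4-methoxyphenyl on a nitrogen on an aromatic ring gives an at least 1.0-fold higher number from compound 1 to compound 4 (0.01 log units; that floor lies within the scatter), a floor that fixes no size for the change. With bromo added, the 2-fluorophenyl, 3-chlorophenyl and 2-bromophenyl groups all end at the same limit of the assay, and this floor does not separate compound 4 from compound 1. The steps from compound 2 to compound 4 and from compound 3 to compound 4 cannot be read, because both ends of each are limits: the limit of > 50000 nM in this assay, at which 3 of the 4 values shown sit.

Any ranking among the three halogen-bearing compounds stays open. Also open, on these data alone, is whether an amine or a carboxylic acid on this aryl ring would give a readable number in this assay.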